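Notes on the step from compound 1 to compound 3

The source may hold more compounds than are shown below. What is called first, only, known or untested is meant among the compounds shown, and "the series" means these compounds.

- compound 1 `CN1CCC=C(c2ccc(CN(C)C/C=C/c3ccccc3)cc2)C1`: > 50000 nM
- compound 2 `CN1CCC=C(c2ccc(CN(C)C/C=C/c3ccc([N+](=O)[O-])cc3)cc2)C1`: > 50000 nM

In an ADME assay on HL-60 cells (Homo sapiens) for cytotoxicity, read by MTT assay, with a stated time of 24 h (on this read-out higher numbers stand for weaker inhibition and lower numbers for stronger inhibition), compound 1 gives > 50000 nM, which is a limit and not a number. Compound 2 gives > 50000 nM, which is also a limit. Compound 3 `CN(C/C=C/c1ccccc1)Cc1ccc(C2CCCN(C)C2)cc1` is not yet measured. It differs from compound 1 as follows: a group of 7 heavy atoms (6 carbon, 1 nitrogen; one six-membered non-aromatic ring with 1 hetero atom) in place of a group of 7 heavy atoms (6 carbon, 1 nitrogen; one six-membered non-aromatic ring with 1 hetero atom), on an aromatic carbon. The group that leaves holds a double bond outside aromatic rings, and the 1-methylpiperidin-3-yl group that enters holds none.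

Among the measured compounds shown here, the only measured step is a step that the two limits leave unreadable from compound 1 to compound 2. It concerns another place and gives no size. What remains is the limit of > 50000 nM in this assay, at which 2 of the 2 values shown sit. For the measured compounds named here, no measured step addresses this ring change, so no step beyond the scatter is expected in this assay, and no direction can be given. Compound 3 is expected to be reported as a limit as well. Compound 3 is estimated at 60000 nM, with an expected range of 30000 nM to 120000 nM. The estimated step is a step that the limit leaves unreadable from compound 1 to compound 3.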

Compound 3, half-maximal inhibitory concentration: > 50000 nM
Compound 3: a limit, no number; the forecaster's own chance of this, stated with the estimate: 80%; the middle value does not contradict the limit.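

Compound 1, compound 2 and compound 3 all stand at a limit and not at a number, so no step among them can be read in this assay: the limit of > 50000 nM in this assay, at which 3 of the 3 values shown sit.

The compounds shown leave open whether any change on the shared core gives a measurable value in this assay.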